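Methoxycarbonyl to carboxy: a second demethylation step

This account rests on a few compounds, and the source may have more. Where it says the series, first, only, none or still open, it means among the compounds named here.

Compound 1 `COc1ccc(-c2cnc(C(=O)CCCCCCc3ccccc3)o2)cc1` is measured in an assay (Rattus norvegicus) for inhibition of Fatty-acid amide hydrolase 1 (Homo sapiens) (a higher number here means a weaker inhibitor, a lower number a stronger inhibitor), and compound 1 gives 100 nM. Compound 2 `O=C(CCCCCCc1ccccc1)c1ncc(-c2ccc(O)cc2)o1` carries hydrogen in place of methyl on an oxygen on an aromatic ring; in this assay compound 2 gives 140 nM, a step of a 1.4-fold higher number from compound 1 to compound 2 (0.15 log units; within the scatter). Compound 3 `COC(=O)c1cccc(-c2cnc(C(O)CCCCCCc3ccccc3)o2)n1` gives 2300 nM in this assay, the highest number of the three; the difference between its core and the core of compound 1 is not broken down here. Compound 4 `O=C(O)c1cccc(-c2cnc(C(O)CCCCCCc3ccccc3)o2)n1` is not yet measured and carries hydrogen in place of methyl on an oxygen next to a carbonyl group. The place differs from the earlier step: there the oxygen sat on an aromatic ring, here on an oxygen next to a carbonyl group, so this is the same kind of change, not the same. The step is expected to be a 1.1-fold higher number from compound 3 to compound 4 (0.04 log units; within the scatter), resting on compound 1 to compound 2, where a 1.4-fold higher number from compound 1 to compound 2 (0.15 log units; within the scatter) stayed within the scatter, with added uncertainty from the differing place. Compound 4 is estimated at 2500 nM in this assay, within 800 nM to 8000 nM.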

Compound 4, inhibition constant: > 10000 nM
Compound 4: only a limit was reported; the forecaster's own chance of this, stated with the estimate: 5%; middle value at least 4.0-fold (0.60 log units) away from the limit.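

Compound 4 gives > 10000 nM in this assay, which is a limit of the assay and not a number. Hydrogen in place of methyl here gives an at least 4.3-fold higher number from compound 3 to compound 4 (0.63 log units; beyond the scatter), so the size of the change does not carry over from one core to the other: the same change on two cores in this assay, a 1.4-fold higher number (0.15 log units; within the scatter) from compound 1 to compound 2 and an at least 4.3-fold higher number (0.63 log units; beyond the scatter) from compound 3 to compound 4, at least 3.1-fold (0.49 log units) apart, beyond the scatter of two such steps. Going by these compounds, with a single pair on each core, the place of the change (on an aromatic ring, or on an oxygen next to a carbonyl group) and the core differ together, so the data do not separate the two, and the full size of the new step stays unknown.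

Open, on these data alone, is how methoxycarbonyl to carboxy reads on the core of compound 1. Also open, as far as these compounds go, is whether an amide in place of the carboxy group stays closer to compound 3 or to compound 4.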